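The source may report more compounds than this note shows. Statements on the series, on what has been measured and on what is new or still open speak of the compounds shown alone.

Of the compounds shown here, three built on one shared core have been measured in an assay on cells for antagonist activity at vitamin D3 receptor (Homo sapiens), read by a luciferase reporter; on this read-out higher numbers stand for weaker inhibition and lower numbers for stronger inhibition. Compound 1 `COC(=O)c1ccccc1OCc1oc(-c2ccccc2OC)nc1C` gives 20200 nM. Compound 2 `COC(=O)c1ccccc1OCc1oc(-c2cccc(OC)c2)nc1C` gives 15400 nM. Compound 3 `COC(=O)c1cccc(OCc2oc(-c3ccccc3OC)nc2C)c1` gives 7330 nM, the lowest number of the three; the gap to compound 2, the nearest of the other two, is beyond the scatter, and the gap to compound 1, the furthest, is larger still. Compound 4 `COC(=O)c1cccc(OCc2oc(-c3cccc(OC)c3)nc2C)c1` has not yet been measured in this assay . It is compound 3 with one change: 3-methoxyphenyl in place of 2-methoxyphenyl on an aromatic carbon. The same change has been seen once before among the measured compounds, as the step of a 1.3-fold lower number from compound 1 to compound 2 (0.12 log units; within the scatter), and that step stayed within the scatter. Going by the values given here, with only that one step as a guide, the change from compound 3 to compound 4 is expected to bring no movement beyond the scatter, so the estimated step is a 1.3-fold lower number from compound 3 to compound 4 (0.10 log units; within the scatter). On that basis compound 4 is expected to give about 5800 nM in this assay , with a range from 2500 nM to 14000 nM to cover the usual spread of such measurements around a single earlier observation.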

Compound 4, half-maximal inhibitory concentration in the vitamin D3 receptor assay: 17100 nM
Compound 4: the middle estimate sits 2.9-fold (0.47 log units) below what was measured; the whole stated range lies below it.
By their numbers in the vitamin D3 receptor assay, from the lowest: compound 3; then compounds 2, 4 and 1 (each within the scatter of the next).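

Putting 3-methoxyphenyl in place of 2-methoxyphenyl does not act the same way on every core: in the vitamin D3 receptor assay, the change now gives a 2.3-fold higher number from compound 3 to compound 4 (0.37 log units; beyond the scatter), a shift that the earlier pair did not show, with a 1.3-fold lower number from compound 1 to compound 2 (0.12 log units; within the scatter). In the vitamin D3 receptor assay, compound 3 gives 7330 nM and compound 4 gives 17100 nM. At this place on the five-membered ring, the outcome of the swap depends on the rest of the molecule, and one earlier step could not reveal that: the same change on two cores in the vitamin D3 receptor assay, a 1.3-fold lower number (0.12 log units; within the scatter) from compound 1 to compound 2 and a 2.3-fold higher number (0.37 log units; beyond the scatter) from compound 3 to compound 4, 3.1-fold (0.49 log units) apart, beyond the scatter of two such steps. In a physicochemical assay for solubility, tested at 500 uM (a lower number here means a less soluble compound, a higher number a more soluble compound), compound 3 gives 44100 nM and compound 4 gives 24100 nM. In the physicochemical assay, the same change gives a 1.8-fold lower number from compound 3 to compound 4 (0.26 log units; within the scatter), so that read-out shows no shift beyond the scatter to set beside the one in the vitamin D3 receptor assay.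

The compounds shown carry only a methoxy group on that outer aromatic ring and keep the methyl ester throughout, so it remains open whether the same dependence on the core would appear with a chlorine atom on the ring or with a carboxylic acid in place of the ester. Going by these compounds alone, with only two pairs available, the data also cannot tell why the two cores respond differently, or whether this difference would hold on any further core.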